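Losing the (prop-1-en-1-yl)carbonyl group from compound 3

The source may hold more compounds than are shown below. What is called first, only, known or untested is meant among the compounds shown, and "the series" means these compounds.

For the measured compounds named here, in a functional assay on KYSE-450 cells (Homo sapiens) for inhibition, read by MTT assay, with a stated time of 48 h (a lower number here means a stronger inhibitor, a higher number a weaker inhibitor), compound 3 `C/C=C/C(=O)N(Cc1ccc(OC)cc1)c1cc(OC)c(OC)c(OC)c1` gives 420 nM as the lowest number measured so far. Compound 2 `COc1ccc(CNc2cc(OC)c(OC)c(OC)c2)cc1C` gives 73800 nM in this assay as a much higher number, and this gap lies beyond the scatter. Compound 1 `COc1cc(NCc2ccc(Br)cc2)cc(OC)c1OC` shows > 80000 nM as its result, which is a limit of the assay and not a number.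

Compound 4 `COc1ccc(CNc2cc(OC)c(OC)c(OC)c2)cc1` has not been measured yet. It differs from compound 3 by one structural change hydrogen in place of (prop-1-en-1-yl)carbonyl on a nitrogen on an aromatic ring in which hydrogen stands in place of (prop-1-en-1-yl)carbonyl on a nitrogen on an aromatic ring. A large move to a higher number is expected in this assay, well beyond the scatter, because compound 2 without that group gives 73800 nM in the same test. The estimated change is a 140-fold higher number from compound 3 to compound 4 (2.15 log units; beyond the scatter) and would mean a much weaker inhibitor. In this assay compound 4 is estimated at 60000 nM with an expected range from 20000 nM to 100000 nM for the measurement.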

Compound 4, half-maximal inhibitory concentration: 4890 nM
The estimate for compound 4 lay 12-fold (1.09 log units) above the measured number; the whole stated range lies above it.
By their numbers in this assay, from the lowest: compound 3; then compound 4; then compound 2. At a limit, above all of these: compound 1.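

With this assay as the test, the (prop-1-en-1-yl)carbonyl group on the nitrogen now has a direct comparison: hydrogen in its place gives a 12-fold higher number from compound 3 to compound 4 (1.07 log units; beyond the scatter), yet compound 4 still keeps a measured number without it. The compounds lacking that group are not uniformly weak either, since hydrogen in place of methyl on an aromatic carbon gives a 15-fold lower number from compound 2 to compound 4 (1.18 log units; beyond the scatter). Methoxy in place of bromo gives an at least 16-fold lower number from compound 1 to compound 4 (1.21 log units; beyond the scatter), but compound 1 stands at a limit and not a number, so this step gives only a bound: the limit of > 80000 nM in this assay, at which 1 of the 4 values shown sits.

From the compounds shown here alone, whether the effect needs the carbon-carbon double bond or only the carbonyl stays open, a saturated propanoyl or a plain acetyl group on that nitrogen being the comparison that would tell. Going by these compounds, how a fluoro or hydroxyl group on that aromatic carbon would compare with methyl also stays open.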